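Adding trifluoromethoxy to the aromatic ring of compound 1

This account rests on a few compounds, and the source may have more. Where it says the series, first, only, none or still open, it means among the compounds named here.

Measured so far in a functional assay on HCT-116 cells (Homo sapiens) for antiproliferative activity, read by WST assay, with a stated time of 72 h; a lower number here means a stronger inhibitor of growth, a higher number a weaker inhibitor of growth:
- compound 1 `O=C(NO)c1cnc(N2C[C@@H]3[C@H](C2)[C@H]3NCc2ccccc2)nc1`: 120 nM
- compound 2 `O=C(NO)c1cnc(N2C[C@@H]3[C@H](C2)[C@H]3NCc2cc(F)cc(F)c2)nc1`: 200 nM

Among the measured compounds shown here, only two compounds have been measured so far. Compound 1 stands at 120 nM and compound 2 at 200 nM. These values lie within the scatter of each other, so the data do not rank them.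

Compound 3 `O=C(NO)c1cnc(N2C[C@@H]3[C@H](C2)[C@H]3NCc2ccc(OC(F)(F)F)cc2)nc1` keeps the rest of compound 1 but has trifluoromethoxy in place of hydrogen on an aromatic carbon, para to a large group: trifluoromethoxy in place of hydrogen on an aromatic carbon.

One measured step offers guidance, as it also alters this aromatic ring. Replacing phenyl with 3,5-difluorophenyl gave a 1.7-fold higher number from compound 1 to compound 2 (0.22 log units; within the scatter). For the measured compounds named here, that is a single step involving a different substituent, so it is only a loose guide, and no measurement yet shows what trifluoromethoxy does here. With that in mind, no change beyond the scatter is expected in this assay, though the uncertainty is wide in both directions.

The expected step is a 1.3-fold higher number from compound 1 to compound 3 (0.10 log units; within the scatter).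

The estimated value for compound 3 is 150 nM, with an expected range of 60 nM to 380 nM.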

Compound 3, concentration for 50% growth inhibition: 120 nM
For compound 3 the middle estimate is 1.3-fold (0.10 log units) above the measured one; the measured number falls inside the stated range.
By their numbers in this assay, from the lowest: compounds 1, 3 and 2 (each within the scatter of the next).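

In this assay, trifluoromethoxy in place of hydrogen on an aromatic carbon, para to a large group, gives no change at the digits printed from compound 1 to compound 3 (within the scatter) and so leaves the reading where it was. Among the compounds shown here, until now, the only change to this ring was 3,5-difluorophenyl in place of phenyl, so this step adds something new: a substituent of 5 heavy atoms, including 1 hydrogen-bond acceptor, can sit at this place on the ring of compound 1 with no loss of growth inhibition beyond the scatter. Nothing available explains why the group is accepted here, so the result stands as an observation without a known cause.

Going by these compounds, whether an amine, a carboxylic acid or a longer chain at this same place would also stay within the scatter of compound 1 remains open. On these data alone, it is equally open whether trifluoromethoxy would give a similar reading on another carbon of this ring in this assay, so the result so far describes one group at one place.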